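Removing the Acetyl Group From a Weak Growth Inhibitor

The source may hold more compounds than are shown below. What is called first, only, known or untested is meant among the compounds shown, and "the series" means these compounds.

compound 1 `CC(=O)N1c2ccccc2CCC1C(=O)Nc1ccccc1O`: 89600 nM
compound 2 `CCC(=O)N1c2ccccc2CCC1C(=O)Nc1cc(C(F)(F)F)cc(C(F)(F)F)c1`: 7280 nM

In a functional assay on MDA-MB-231 cells (Homo sapiens) for cytotoxicity, read by sulforhodamine B assay, with a stated time of 72 h (a lower number here means a stronger inhibitor of growth, a higher number a weaker inhibitor of growth), compound 1 gives 89600 nM, the highest of the two numbers. Compound 2, which differs from it in two places, gives 7280 nM, a lower number beyond the scatter. Compound 3 `O=C(Nc1ccccc1O)C1CCc2ccccc2N1` has not been measured. It differs from compound 1 by hydrogen in place of acetyl on a nitrogen on an aromatic ring in a ring. For the measured compounds named here, no measured pair shows this change alone, and compound 2 changes elsewhere as well, so nothing measured speaks to this step. Expected here is a 1.1-fold higher number from compound 1 to compound 3 (0.05 log units; within the scatter), not beyond the scatter. Compound 3 is therefore estimated at 100000 nM, between 30000 nM and 300000 nM.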

Compound 3, concentration for 50% growth inhibition: 5260 nM
Beside the measured number, compound 3's estimate is 19-fold (1.28 log units) above it, and the stated range ends above it.
By their numbers in this assay, from the lowest: compounds 3 and 2 (each within the scatter of the next); then compound 1.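

In this assay, for the compounds shown here, the acetyl group on this nitrogen proves unnecessary for growth inhibition: replacing it with hydrogen gives a 17-fold lower number from compound 1 to compound 3 (1.23 log units; beyond the scatter) and is the first change at this position to be read alone. Of the two forms compared here, the nitrogen bearing only hydrogen is clearly the stronger inhibitor. Nothing available explains this gain. As far as these compounds go, what a methyl group or a longer carbon chain on this nitrogen would do remains open, as does whether removing the acetyl group has a similar effect in other compounds.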